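Methyl for trifluoromethyl on the indole core of compound 1

A few compounds are considered here, and "the series" means these few. Any claim that something is new, unique, unknown or untested is made for them only; others in the source may bear on it.

Measured compounds:
compound 1, `O=C(/C=C/c1ccc(OCCO)c(OCCO)c1)NCCn1c(C(F)(F)F)cc2ccccc21`: 260 nM
compound 2, `COc1cc(/C=C/C(=O)NCCn2c(C)cc3ccccc32)cc(OC)c1OCCO`: 3.7 nM
compound 3, `COc1cc(/C=C/C(=O)NCCn2c(C(F)(F)F)cc3ccccc32)cc(OC)c1OCCO`: 58.3 nM

In an assay on C6 cells for antagonist activity at prostaglandin E2 receptor EP2 subtype (Homo sapiens), read by TR-FRET, with stated times of 10 min and 40 min, tested at 1 uM (a lower number here means a stronger inhibitor, a higher number a weaker inhibitor), compound 1 gives 260 nM, the highest number of the three; compound 3 gives 58.3 nM and compound 2 gives 3.7 nM. Compounds 3 and 2 differ in one place, (methyl in place of trifluoromethyl on an aromatic carbon), and that change made a step of a 16-fold lower number from compound 3 to compound 2 (1.20 log units; beyond the scatter). Compound 4, `Cc1cc2ccccc2n1CCNC(=O)/C=C/c1ccc(OCCO)c(OCCO)c1`, is not yet measured; it differs from compound 1 in the same way, (methyl in place of trifluoromethyl on an aromatic carbon), the same change on the same kind of place. The difference between the cores of compound 1 and compound 3 is not broken down here. Among the measured compounds shown here, since the one measured example of this change gave a 16-fold lower number from compound 3 to compound 2 (1.20 log units; beyond the scatter), a step of similar size is expected from compound 1, a 13-fold lower number from compound 1 to compound 4 (1.11 log units; beyond the scatter). Compound 4 is therefore estimated at 20 nM in this assay, with a range of 6 nM to 70 nM.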

Compound 4, antagonist equilibrium constant in the prostaglandin E2 receptor EP2 subtype assay: 11.4 nM
For compound 4 the middle estimate is 1.8-fold (0.24 log units) above the measured one; measured number inside the range.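

In the prostaglandin E2 receptor EP2 subtype assay, compound 1 gives 260 nM and compound 4 gives 11.4 nM. In the prostaglandin E2 receptor EP2 subtype assay, methyl in place of trifluoromethyl gave a 23-fold lower number from compound 1 to compound 4 (1.36 log units; beyond the scatter). The two cores shown could not be told apart in the size of this step: the same change on two cores in the prostaglandin E2 receptor EP2 subtype assay, a 16-fold lower number (1.20 log units; beyond the scatter) from compound 3 to compound 2 and a 23-fold lower number (1.36 log units; beyond the scatter) from compound 1 to compound 4, 1.4-fold (0.16 log units) apart, within the scatter of two such steps. This rests on two pairs only, so it shows that the step carried between these two cores, not that it would carry to any other core, and it does not explain the lower number. In a physicochemical assay for solubility, read by nephelometry, in phosphate buffer, at pH 7.4 (a lower number here means a less soluble compound, a higher number a more soluble compound), compound 1 gives 67000 nM and compound 4 gives 153000 nM. In the physicochemical assay, the same change gave a 2.3-fold higher number from compound 1 to compound 4 (0.36 log units; beyond the scatter), but this single pair has no second core to compare with.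

The compounds shown leave open how another group at this place, such as ethyl, chlorine or a nitrile, would compare with methyl and trifluoromethyl. They also leave open whether the step would hold on a core carrying a carboxylic acid or an amine.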